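A few compounds are considered here, and "the series" means these few. Any claim that something is new, unique, unknown or untested is made for them only; others in the source may bear on it.

Within the data shown here, in a functional assay on MDA-MB-231 cells (Homo sapiens) for antiproliferative activity, read by sulforhodamine B assay, with a stated time of 48 h (on this read-out lower numbers stand for stronger inhibition and higher numbers for weaker inhibition), compound 1 `COc1ccc(C(=O)/C=C\Nc2ccc(-c3nc4cc(OC)c(OC)c(OC)c4s3)cc2C)cc1F` gives 2900 nM, the lowest of the three numbers measured so far. Compound 2 `COc1ccc(C(=O)/C=C\Nc2ccc(-c3nc4cc(OC)c(OC)c(OC)c4s3)cc2C)cc1[N+](=O)[O-]` gives 12400 nM, and compound 3 `COc1cc(OC)c2sc(-c3ccc(N/C=C\C(=O)c4ccc(OC)c(F)c4)c(C)c3)nc2c1` gives 13300 nM. The still unmeasured compound 4 `COc1ccc(C(=O)/C=C\Nc2ccc(-c3nc4cc(OC)c(OC)c(OC)c4s3)cc2)cc1F` differs from compound 1 in one place: hydrogen in place of methyl on an aromatic carbon. Among the measured compounds shown here, no measured step touches this methyl, so the evidence is only indirect. Nitro in place of fluoro on an aromatic carbon gave a 4.3-fold higher number from compound 1 to compound 2 (0.63 log units; beyond the scatter), and hydrogen in place of methoxy on an aromatic carbon gave a 4.6-fold higher number from compound 1 to compound 3 (0.66 log units; beyond the scatter). Both steps are modest, both involve other groups, and neither shows which way losing the methyl will go. A step no larger than these is therefore expected in this assay, quite possibly none beyond the scatter, with no firm direction. The estimated step is a 1.2-fold higher number from compound 1 to compound 4 (0.08 log units; within the scatter). For compound 4 the expected value is 3500 nM, with an estimated range from 1000 nM to 12000 nM.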

Compound 4, half-maximal inhibitory concentration: 16500 nM
Beside the measured number, compound 4's estimate is 4.7-fold (0.67 log units) below it; the whole stated range lies below it.
By their numbers in this assay, from the lowest: compound 1; then compounds 2, 3 and 4 (each within the scatter of the next).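

In this assay the change at this aromatic carbon can now be read directly: hydrogen in place of methyl gives a 5.7-fold higher number from compound 1 to compound 4 (0.76 log units; beyond the scatter) and so shows that a single carbon atom here, ortho to a large group and meta to a large group, makes a real difference to the number. All three single changes away from compound 1 now lead to a higher number, and none lowers it, so the methyl belongs with the fluoro and the methoxy as a group whose change costs activity among these compounds. Nothing measured here explains why the methyl matters.

Still open, as far as these compounds go, is whether an ethyl group or a chlorine atom on this same carbon would match the methyl, or even give a lower number. An amine there is equally untested by the compounds shown, so how much room this position allows remains unknown.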